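Swapping Azide for Bromide on the Acetamide Chain

A few compounds are considered here, and "the series" means these few. Any claim that something is new, unique, unknown or untested is made for them only; others in the source may bear on it.

Three amides built on one shared core have been measured in a functional assay on HCT-116 cells (Homo sapiens) for inhibition, read by MTT assay, with a stated time of 48 h; on this read-out higher numbers stand for weaker inhibition and lower numbers for stronger inhibition. Compound 1 `COc1ccc(CN(C(=O)C2CC2)c2cc(OC)c(OC)c(OC)c2)cc1O` gives 49 nM. Compound 2 `COc1ccc(CN(C(=O)C=C(C)C)c2cc(OC)c(OC)c(OC)c2)cc1O` gives 290 nM. Compound 3 `COc1ccc(CN(C(=O)CN=[N+]=[N-])c2cc(OC)c(OC)c(OC)c2)cc1O` gives 410 nM, the highest of the three numbers; its nearest neighbour is compound 2, and the step of a 1.4-fold higher number from compound 2 to compound 3 (0.15 log units; within the scatter) lies within the scatter, whereas the step of an 8.4-fold higher number from compound 1 to compound 3 (0.92 log units; beyond the scatter) lies beyond it, as does a 5.9-fold higher number from compound 1 to compound 2 (0.77 log units; beyond the scatter).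

Compound 4 `COc1ccc(CN(C(=O)CBr)c2cc(OC)c(OC)c(OC)c2)cc1O` is the next member. The change from compound 3 to compound 4 is bromo in place of azido on a saturated chain carbon bound to a carbonyl carbon. For the measured compounds named here, none of the measured steps touches this position: the steps from compound 1 replace the whole group on the carbonyl carbon, and the step between compound 2 and compound 3 is within the scatter. Going by the values given here, with no step bearing directly on the azido-to-bromo exchange, a change no larger than the scatter is expected, a 1.4-fold lower number from compound 3 to compound 4 (0.14 log units; within the scatter). Compound 4 is therefore estimated at 300 nM, in the range 100 nM to 900 nM.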

Compound 4, half-maximal inhibitory concentration: 68 nM
Compound 4: middle estimate off by 4.4-fold (0.64 log units), on the high side; the whole stated range lies above it.
By their numbers in this assay, from the lowest: compounds 1 and 4 (each within the scatter of the next); then compounds 2 and 3 (each within the scatter of the next).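

For the compounds shown here, at the saturated chain carbon bound to a carbonyl carbon, the choice of group counts in this assay: exchanging azido for bromo alone moves the read-out beyond the scatter (a 6.0-fold lower number from compound 3 to compound 4 (0.78 log units; beyond the scatter)), which the earlier steps, each replacing the whole group on the carbonyl carbon, could not show. The bromomethyl amide also separates from the 2-methylprop-1-en-1-yl amide (a 4.3-fold lower number from compound 2 to compound 4 (0.63 log units; beyond the scatter)), yet it cannot be told apart from the cyclopropyl amide (a 1.4-fold higher number from compound 1 to compound 4 (0.14 log units; within the scatter)), so a group on this chain carbon can bring a flexible chain level with the ring. Nothing available explains why bromo and azido differ here.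

As far as these compounds go, whether this result is particular to bromo or extends to chloro or iodo on the same carbon remains open. So does the outcome with an amine or a hydroxyl group at this place.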